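A Triple Bond in Place of a Double Bond

A few compounds are considered here, and "the series" means these few. Any claim that something is new, unique, unknown or untested is made for them only; others in the source may bear on it.

Compound 1 `Nc1ncnc2c1ncn2C/C=C/CCl`: 45000 nM
Compound 2 `Cc1cn(C/C=C\CO)c(=O)[nH]c1=O`: > 1000000 nM (a limit of the assay)

Going by the values given here, in a functional assay on L1210 cells (Mus musculus) for inhibition (on this read-out higher numbers stand for weaker inhibition and lower numbers for stronger inhibition), compound 1 gives 45000 nM as the only true number so far. Compound 2 stands at > 1000000 nM in the same read-out, and this is a limit, not a number.

Compound 3 (`Nc1ncnc2c1ncn2CC#CCCl`) keeps the core of compound 1 and carries 3-chloroprop-1-yn-1-yl in place of 3-chloroprop-1-en-1-yl on a saturated chain carbon bound to an aromatic nitrogen. Cut one bond further out, this is 4-chlorobut-2-en-1-yl to 4-chlorobut-2-yn-1-yl. Among the compounds with values here, no measured pair shows what such a change does, so no direction is favoured. The expectation is a 1.1-fold lower number from compound 1 to compound 3 (0.05 log units; within the scatter) and no more than a small shift. In this assay compound 3 is expected at 40000 nM with 10000 nM to 160000 nM as its estimated range.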

Compound 3, half-maximal inhibitory concentration: 90000 nM
Beside the measured number, compound 3's estimate is 2.3-fold (0.35 log units) below it; the measured number falls inside the stated range.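

In this assay, going by these compounds alone, the first step that can be read at this position is a 2.0-fold higher number from compound 1 to compound 3 (0.30 log units; within the scatter). On a saturated chain carbon bound to an aromatic nitrogen, 3-chloroprop-1-yn-1-yl can thus take the place of 3-chloroprop-1-en-1-yl on the shared core with no change that stands clear of the scatter, and the result says nothing about why. Compound 2 gives no second step, and its value is a limit, not a number: the limit of > 1000000 nM in this assay, at which 1 of the 3 values shown sits.

The compounds shown leave open what the chlorine contributes to either chain, since it is present in both compound 1 and compound 3. A bromine or an amine in its place, or a longer chain carrying the triple bond, would show whether this position responds to any change at all.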